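A few compounds are considered here, and "the series" means these few. Any claim that something is new, unique, unknown or untested is made for them only; others in the source may bear on it.

Measured compounds:
- compound 1, `CCCOC(=O)C1=C(C)NC(=O)NC1c1cccs1`: 43%
- compound 2, `CCCOC(=O)C1=C(C)NC(=O)NC1c1ccsc1`: 44%
- compound 3, `CCC(CC)OC(=O)C1=C(C)NC(=O)NC1c1cccs1`: 13%

All three numbers come from an assay on membranes from CHO cells for displacement of a labelled ligand from adenosine receptor A1 (Homo sapiens), read by scintillation counting, with a stated time of 60 min, tested at 1 uM; on this read-out higher numbers stand for more inhibition at the one concentration tested (going by the name of the read-out) and lower numbers for less inhibition. Compound 1 and compound 2 share the propoxycarbonyl group and differ only by thiophen-3-yl in place of thiophen-2-yl on a saturated ring carbon; this gave a number 1 percentage points higher from compound 1 to compound 2 (within the scatter), so the two thiophene attachments read the same here. Compound 1 and compound 3 differ by ethyl in place of hydrogen on a saturated chain carbon bound to an oxygen next to a carbonyl group and a saturated chain carbon; this gave a number 30 percentage points lower from compound 1 to compound 3 (beyond the scatter), and compound 3 stands lowest of the three, with both other compounds beyond the scatter above it.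

Compound 4, `CCC(CC)OC(=O)C1=C(C)NC(=O)NC1c1ccsc1`, is not yet measured. It differs from compound 3 by thiophen-3-yl in place of thiophen-2-yl on a saturated ring carbon. Within the data shown here, this is the same kind of change as the one from compound 1 to compound 2, but not the same: around the place, the ring atom bears "a group of 8 heavy atoms" in the pair compound 3 to compound 4, where it bears "a propoxycarbonyl group (6 heavy atoms)" in the pair compound 1 to compound 2. The two cores differ by ethyl in place of hydrogen on a saturated chain carbon bound to an oxygen next to a carbonyl group and a saturated chain carbon.

For compound 4 the step of a number 1 percentage points higher from compound 3 to compound 4 (within the scatter) is expected, beside the earlier a number 1 percentage points higher from compound 1 to compound 2 (within the scatter), because a number 1 percentage points higher from compound 1 to compound 2 (within the scatter) lay within the scatter and nothing in the three numbers suggests the thiophene attachment matters on either core. Compound 4 is thus estimated at 14%, expected to fall between 2% and 28%.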

Compound 4, a percentage reported as inhibition, at one concentration (the size of the read-out at that concentration, not a potency): 22%
Compound 4: the middle estimate sits 8 percentage points below what was measured; low and high end bracket the measured number.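

In this assay, thiophen-3-yl in place of thiophen-2-yl gave a number 9 percentage points higher from compound 3 to compound 4 (within the scatter), so on the core bearing the group of 8 heavy atoms the change reads as it did on the core bearing the propoxycarbonyl group: the same change on two cores in this assay, a number 1 percentage points higher (within the scatter) from compound 1 to compound 2 and a number 9 percentage points higher (within the scatter) from compound 3 to compound 4, 8 percentage points apart, within the scatter of two such steps. Ethyl in place of hydrogen on the saturated chain carbon bound to the oxygen also carries across the two thiophene attachments, giving a number 22 percentage points lower from compound 2 to compound 4 (beyond the scatter) on the thiophen-3-yl compounds, and this step stands level with the earlier one on the thiophen-2-yl compounds: the same change on two cores in this assay, a number 30 percentage points lower (beyond the scatter) from compound 1 to compound 3 and a number 22 percentage points lower (beyond the scatter) from compound 2 to compound 4, 8 percentage points apart, within the scatter of two such steps. This shows that within these four compounds the two changes combine without a detectable departure from one core to the other, but it does not show that the thiophene attachment matters on either core, and it rests on two pairs read at one concentration, which gives no potency.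

Still open, from the compounds shown here alone, is how a butyl ester or a benzyl ester in place of the propoxycarbonyl group would read in this assay, and whether the drop seen with the larger ester group continues along such a series. Equally open, going by these compounds, is whether a phenyl group or a furan-2-yl group in place of the thiophene would move the number beyond the scatter on either core.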